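A few compounds are considered here, and "the series" means these few. Any claim that something is new, unique, unknown or untested is made for them only; others in the source may bear on it.

Of the compounds shown here, two of one series have been measured in a functional assay on SK-OV-3 cells (Homo sapiens) for cytotoxicity, read by MTT assay, with a stated time of 2 days; on this read-out higher numbers stand for weaker inhibition and lower numbers for stronger inhibition. Compound 1, `Fc1ccc2c(c1)/C(=N\OCc1ccccc1)C(c1c[nH]c3ccc(F)cc13)=N2`, gives in this assay 12300 nM. Compound 2, `Cc1ccc(CO/N=C2/C(c3c[nH]c4ccc(Br)cc34)=Nc3ccc(Br)cc32)cc1`, gives in this assay 7220 nM, the lower of the two numbers, though its gap to compound 1 falls within the scatter, so the two show the same level.

Compound 3, `FC(F)(F)c1ccc(CO/N=C2/C(c3c[nH]c4ccc(Br)cc34)=Nc3ccc(Br)cc32)cc1`, is the next step. It differs from compound 2 by trifluoromethyl in place of methyl on an aromatic carbon. Among the measured compounds shown here, no measured pair in this set carries such a change, so nothing here tells how large a step it brings. With compound 2 at 7220 nM, the step from compound 2 to compound 3 in this assay is expected to be small, a 1.2-fold lower number from compound 2 to compound 3 (0.08 log units; within the scatter), and not beyond the scatter. Compound 3 is therefore estimated at 6000 nM in this assay, within a range from 2500 nM to 15000 nM.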

Compound 3, half-maximal inhibitory concentration: 10200 nM
Compound 3: middle estimate off by 1.7-fold (0.23 log units), on the low side; measured number inside the range.
By their numbers in this assay, from the lowest: compounds 2, 3 and 1 (each within the scatter of the next).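

Trifluoromethyl in place of methyl on this aromatic carbon gives a 1.4-fold higher number from compound 2 to compound 3 (0.15 log units; within the scatter) in this assay, the only step that can be read in this set. This position, para to a large group, therefore takes the group with more heavy atoms without any change that can be told from the scatter. Nothing at hand offers an explanation for this result.

From the compounds shown here alone, it remains open whether an amine, a carboxylic acid or a longer chain at this same place would move the number beyond the scatter. Compound 1 differs from compound 2 in more than one place, so the share of the halogens on the core and that of the group on the benzyl ring cannot be read apart.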